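Pyridyl for methoxyphenyl on the amide series

A few compounds are considered here, and "the series" means these few. Any claim that something is new, unique, unknown or untested is made for them only; others in the source may bear on it.

Working notes. Of the compounds shown here, two so far have numbers in an assay on cells for inhibition of sodium- and chloride-dependent glycine transporter 1 (Homo sapiens); on this read-out higher numbers stand for an effect only at larger amounts of compound and lower numbers for an effect already at smaller amounts. Compound 1 `COc1cccc(C(F)(F)F)c1C(=O)NC1(c2ccccc2)CCCN(C)C1` gives 1500 nM. Going by the values given here, compound 2 `COc1ccc(C2(NC(=O)c3c(OC)cc(C(F)(F)F)cc3SC)CCCN(C)C2)cc1` gives 170 nM, the lowest of the two numbers; its gap to compound 1 lies beyond the scatter, but the two structures differ in several places at once, so the pair shows only that compound 2 is the more potent of the two, not which part of the structure carries that.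

Compound 3 `COc1cc(C(F)(F)F)cc(SC)c1C(=O)NC1(c2cccnc2)CCCN(C)C1` keeps the amide and the methylated ring of compound 2 and changes one thing: pyridin-3-yl in place of 4-methoxyphenyl on a saturated ring carbon. Among the compounds with values here, no measured pair in the set isolates this change, so there is no measured step to lean on. The expectation is a modest loss in this assay, a step of a 2.4-fold higher number from compound 2 to compound 3 (0.37 log units; beyond the scatter), somewhat beyond the scatter but not large. Compound 3 is therefore expected to give 400 nM in this assay, with a range from 120 nM to 1500 nM.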

Compound 3, half-maximal effective concentration: 54 nM
Beside the measured number, compound 3's estimate is 7.4-fold (0.87 log units) above it, outside the stated range (below it).
By their numbers in this assay, from the lowest: compound 3; then compound 2; then compound 1.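

In this assay, going by these compounds alone, the swap of 4-methoxyphenyl for pyridin-3-yl on the saturated ring carbon gives a 3.1-fold lower number from compound 2 to compound 3 (0.50 log units; beyond the scatter) and so provides the first measured step at a single place, which the earlier pair, differing in several places at once, could not provide. The 4-methoxyphenyl group is therefore not required at this place for activity on the amide and methylated ring shared by these two compounds, and a smaller aromatic ring with one hetero atom is tolerated and gives the lower number. Nothing at hand explains the direction of this step.

Within the data shown here, the single step does not separate the loss of the methoxy group from the entry of the ring nitrogen, and pyridin-2-yl, pyridin-4-yl or pyrimidin-5-yl on this carbon would be needed to show whether the place of that nitrogen matters. Among these compounds, it also remains open whether the same swap gives a step of similar size with a different amide part, such as the one in compound 1.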